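Ethyl to cyclopropyl on compound 2

The source may report more compounds than this note shows. Statements on the series, on what has been measured and on what is new or still open speak of the compounds shown alone.

Compound 1 `COc1cc(C2CN(C(=O)c3cc(OC[C@H](O)CO)ccn3)C2)ccc1OCc1ccc(C2CC2)cc1` gives 67%
Compound 2 `CCc1ccc(COc2ccc(C3CN(C(=O)c4cc(COCC(CO)(CO)CO)ccn4)C3)cc2OC)cc1` gives 71%

In an ADME assay on S9 fraction from liver (Mus musculus, strain CD-1) for metabolic stability, read by LC-MS, using NADPH, with stated times of 5 min and 60 min, tested at 5 uM (on this read-out lower numbers stand for a less stable compound and higher numbers for a more stable compound), compound 2 gives 71% and this lies within the usual scatter of compound 1 at 67% so the two cannot be ranked. Compound 3 `COc1cc(C2CN(C(=O)c3cc(COCC(CO)(CO)CO)ccn3)C2)ccc1OCc1ccc(C2CC2)cc1` is compound 2 with cyclopropyl in place of ethyl on an aromatic carbon, para to a large group (cyclopropyl in place of ethyl on an aromatic carbon). Going by the values given here, no measured pair shows this change alone, so its size has no direct precedent. Among the compounds with values here, the only indirect guide is compound 1, which also carries the 4-cyclopropylbenzyl group and gives 67% in this assay on a different side chain. No step beyond the scatter is therefore expected, in either direction. The expected step is a number 3 percentage points lower from compound 2 to compound 3 (within the scatter) and it is estimated to stay within the scatter. The estimated value for compound 3 is 68% with an expected range of 55% to 80% on this read-out.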

Compound 3, percent of the compound remaining: 81%
For compound 3 the middle estimate is 13 percentage points below the measured one; the measured number lies above the stated range.
By their numbers in this assay, from the lowest: compounds 1, 2 and 3 (each within the scatter of the next, the first and the last beyond it).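

In this assay, going by these compounds alone, cyclopropyl in place of ethyl on the aromatic carbon gives a number 10 percentage points higher from compound 2 to compound 3 (within the scatter), the first direct reading of this change, so on this side chain the two groups cannot be told apart. With the 4-cyclopropylbenzyl group held constant, (3-hydroxy-2,2-bis(hydroxymethyl)propoxy)methyl in place of 2,3-dihydroxypropoxy on the aromatic carbon gives a number 14 percentage points higher from compound 1 to compound 3 (beyond the scatter), the only step among these compounds that clears the scatter, which points to the side chain rather than the benzyl substituent as the place where a difference can be read. Nothing measured here accounts for either step.

On these data alone, it remains open whether an isopropyl or a tert-butyl group on that aromatic carbon would read as ethyl and cyclopropyl do. As far as these compounds go, it is equally open how an amine or a carboxylic acid at the end of the side chain would read.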